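TRPV1 antagonist series: replacing the pyrrolidine with a pentyl chain

The source may report more compounds than this note shows. Statements on the series, on what has been measured and on what is new or still open speak of the compounds shown alone.

Measured compounds:
compound 1 `CCCOc1nc(C(C)(C)C)ccc1CNC(=O)C(C)c1ccc(NS(C)(=O)=O)c(F)c1`: 1.7 nM
compound 2 `CCCCOc1nc(C(C)(C)C)ccc1CNC(=O)C(C)c1ccc(NS(C)(=O)=O)c(F)c1`: 0.9 nM
compound 3 `CC(C(=O)NCc1ccc(C(C)(C)C)cc1N1CCCC1)c1ccc(NS(C)(=O)=O)c(F)c1`: 8.1 nM

All three share the amide and fluorinated methanesulfonamide part and differ only on the other aromatic ring. In an assay on cells for antagonist activity at transient receptor potential cation channel subfamily V member 1 (Homo sapiens), read by FLIPR and calcium flux, with a stated time of 6 min (a higher number here means a weaker inhibitor, a lower number a stronger inhibitor), compound 3 gives the highest number of the three; its nearest neighbour is compound 1, and compound 2 lies furthest from it. For the measured compounds named here, the one step between compounds that differ in a single place, a 1.9-fold lower number from compound 1 to compound 2 (0.28 log units; within the scatter), concerns the length of the alkoxy chain and lies within the scatter.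

Compound 4 `CCCCCc1cc(C(C)(C)C)ccc1CNC(=O)C(C)c1ccc(NS(C)(=O)=O)c(F)c1` is not yet measured. It differs from compound 3 as follows: pentyl in place of pyrrolidin-1-yl on an aromatic carbon. Going by the values given here, no measured step touches this change, since the pyrrolidin-1-yl group appears only in compound 3 and neither compound 1 nor compound 2 carries a pentyl group. Compounds 1 and 2 do carry a chain ortho to the large group, and both give lower numbers than compound 3, but that comparison mixes several changes at once. The expectation is therefore a modest step, a 1.6-fold lower number from compound 3 to compound 4 (0.21 log units; within the scatter), toward a lower number, with wide uncertainty. Compound 4 is estimated at 5 nM in this assay, within a range of 1.5 nM to 16 nM.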

Compound 4, inhibition constant: 2.8 nM
Estimate against measurement, compound 4: 1.8-fold (0.25 log units) above; measured number inside the range.
By their numbers in this assay, from the lowest: compounds 2, 1 and 4 (each within the scatter of the next, the first and the last beyond it); then compound 3.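

In this assay, for the compounds shown here, a 2.9-fold lower number from compound 3 to compound 4 (0.46 log units; beyond the scatter) gives the first measured change at this place, ortho to a large group and meta to a tert-butyl group. Pentyl has the same count of heavy atoms as pyrrolidin-1-yl but no ring, no nitrogen and no hydrogen-bond acceptor, and compound 4 still reads 2.8 nM, so neither the ring nor the nitrogen of pyrrolidin-1-yl is required for strong inhibition in this series. Nothing measured here accounts for the size of this step.

Still open, on these data alone, is whether the loss of the ring or the loss of the nitrogen drives the step, which a cyclopentyl group or a diethylamino group at this place would separate. Also open, as far as these compounds go, is how chain length acts here, with butyl or hexyl as the obvious neighbours of pentyl.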